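The source may report more compounds than this note shows. Statements on the series, on what has been measured and on what is new or still open speak of the compounds shown alone.

Measured compounds:
compound 1 `Cc1nn(C(=O)C2CCC2)c(N)c1-c1ccc(Cl)c(Cl)c1` — > 100000 nM
compound 2 `Cc1nn(C(=O)c2cccnc2)c(N)c1-c1ccc(Cl)c(Cl)c1` — > 100000 nM
compound 3 `Cc1c(-c2ccc(Cl)c(Cl)c2)c(N)nn1C(=O)C1CCC1` — > 100000 nM

In an assay on Sf9 cells for inhibition of inhibitor of nuclear factor kappa-B kinase subunit epsilon (Homo sapiens), read by ADP-Glo, with a stated time of 60 min (on this read-out higher numbers stand for weaker inhibition and lower numbers for stronger inhibition), compound 1 gives > 100000 nM, which is a limit of the assay and not a number. Compound 2 gives > 100000 nM, also a limit. Compound 3 gives > 100000 nM, again a limit. The change from compound 1 to compound 2 is pyridin-3-yl in place of cyclobutyl on a carbonyl carbon, and the step that the two limits leave unreadable from compound 1 to compound 2 cannot be read because both ends are limits. Compound 1 and compound 3 share the same atoms joined differently; the difference between the two cores is not broken down here.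

Compound 4 `Cc1c(-c2ccc(Cl)c(Cl)c2)c(N)nn1C(=O)c1cccnc1` is not yet measured. It arises from compound 3 by pyridin-3-yl in place of cyclobutyl on a carbonyl carbon, the same change as that from compound 1 to compound 2, made at the same place. Nothing in the series so far gives a direction for it: the limit of > 100000 nM in this assay, at which 3 of the 3 values shown sit, holds for every measured value, so the change has not yet shown any readable effect.

For compound 4 the expected step of a number no higher from compound 3 to compound 4 (the limit leaves the size open) is therefore estimated as essentially none, resting on (the limit of > 100000 nM in this assay, at which 3 of the 3 values shown sit). Compound 4 is expected to give 100000 nM in this assay, with an estimated range of 50000 nM to 300000 nM, most likely reported only as a limit.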

Compound 4, half-maximal inhibitory concentration: > 100000 nM
Compound 4: no number, only a limit (the forecaster's own chance of this, stated with the estimate: 90%); the middle value lies on the limit itself.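

No step can be read from compound 3 to compound 4, because both values are limits of the assay and not numbers: the limit of > 100000 nM in this assay, at which 4 of the 4 values shown sit.

The compounds shown leave open whether pyridin-3-yl in place of cyclobutyl on a carbonyl carbon has any effect in this assay, and what would bring either core to a readable value.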